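The source may hold more compounds than are shown below. What is called first, only, known or untested is meant among the compounds shown, and "the series" means these compounds.

Two compounds of this series carry numbers in a functional assay on K562 cells (Homo sapiens) for activation; on this read-out higher numbers stand for an effect only at larger amounts of compound and lower numbers for an effect already at smaller amounts. Compound 1 `CO[C@H]1C[C@H](C)Cc2cc(O)cc(c2)NC(=O)/C=C/CC[C@H](OC)[C@@H](OC(N)=O)/C(C)=C/[C@H](C)[C@H]1O` gives 11000 nM. Compound 2 `COc1c2cc(cc1OC(C)=O)NC(=O)/C(C)=C/CC[C@H](OC)[C@@H](OC(N)=O)/C(C)=C/[C@H](C)[C@@H](O)[C@@H](OC)C[C@H](C)C2` gives 230 nM, the lower of the two numbers and beyond the scatter from compound 1. The step now taken leads to compound 3 `COc1c(O)cc2cc1C[C@@H](C)C[C@H](OC)[C@H](O)[C@@H](C)/C=C(\C)[C@H](OC(N)=O)[C@@H](OC)CC/C=C(\C)C(=O)N2`: hydrogen in place of acetyl on an oxygen on an aromatic ring. Within the data shown here, no measured pair shows this change, so its effect cannot be read from earlier values; a small shift toward lower numbers, or none beyond the scatter, is expected, as a 1.5-fold lower number from compound 2 to compound 3 (0.19 log units; within the scatter). Compound 3 is estimated at 150 nM, in the range 40 nM to 600 nM.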

Compound 3, half-maximal effective concentration: 760 nM
Beside the measured number, compound 3's estimate is 5.1-fold (0.70 log units) below it, outside the stated range (above it).
By their numbers in this assay, from the lowest: compound 2; then compound 3; then compound 1.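

Acetoxy to hydroxy on the aromatic ring is the only single-place change readable so far, and in this assay it gives a 3.3-fold higher number from compound 2 to compound 3 (0.52 log units; beyond the scatter) as a modest step. The number at this oxygen therefore depends on what the oxygen carries, with the acetyl form the lower of the pair. No data shown explain the shift. Open, as far as these compounds go, is how a methyl ether, a propionyl ester or a carbamate would read on this oxygen. From the compounds shown here alone, whether the step holds on a different core also stays open.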